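This account rests on a few compounds, and the source may have more. Where it says the series, first, only, none or still open, it means among the compounds named here.

Measured so far:
compound 1, `C/C=C/COc1ccc(C(CC(=O)O)c2ccccc2)cc1`, 2.71 uM
compound 2, `COCCCOc1ccc(C(CC(=O)O)c2ccccc2)cc1`, 7.58 uM

In a functional assay on HEK293 cells for agonist activity at Free fatty acid receptor 1 (Homo sapiens), read by calcium flux (a lower number here means that less compound is needed, a higher number that more compound is needed for the effect), compound 2 stands highest of the two numbers; its nearest neighbour is compound 1, which in this assay gives 2.71 uM. Going by the values given here, the one measured step, a 2.8-fold higher number from compound 1 to compound 2 (0.45 log units; beyond the scatter), bears directly on the change that leads to compound 3, `CCC(C)COc1ccc(C(CC(=O)O)c2ccccc2)cc1`, since it runs over the same place on the shared core. That change reads (sec-butyl in place of 2-methoxyethyl on a saturated chain carbon bound to an oxygen on an aromatic ring). Where the step from compound 1 to compound 2 brought a chain carrying an oxygen in, the step to compound 3 takes that oxygen out again and leaves an all-carbon chain of the same length, closer in kind to compound 1. The number for compound 3 is therefore expected to move back down by about a 2.4-fold lower number from compound 2 to compound 3 (0.37 log units; beyond the scatter) in this assay. Compound 3 is estimated at 3.2 uM, with a range from 1.5 uM to 8 uM.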

Compound 3, concentration for half-maximal effect: 0.3 uM
Beside the measured number, compound 3's estimate is 11-fold (1.03 log units) above it; measured number below the stated range.
By their numbers in this assay, from the lowest: compound 3; then compound 1; then compound 2.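

In this assay, the place on a saturated chain carbon bound to an oxygen on an aromatic ring proves far more responsive than the first step showed: sec-butyl in place of 2-methoxyethyl gives a 25-fold lower number from compound 2 to compound 3 (1.40 log units; beyond the scatter) and is the largest step seen here. Sec-butyl in place of prop-1-en-1-yl also gives a 9.0-fold lower number from compound 1 to compound 3 (0.96 log units; beyond the scatter) even though neither group carries an oxygen, so the loss of the chain oxygen alone cannot describe the order of these three compounds. Nothing available here explains the size of either step.

The compounds shown leave open whether an unbranched pentyl chain, a cyclopentyl ring or a longer chain would give a similarly low number at this place. They also leave open whether the two mirror-image forms of the 2-methylbutyl group differ.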